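A few compounds are considered here, and "the series" means these few. Any claim that something is new, unique, unknown or untested is made for them only; others in the source may bear on it.

Compound 1, `O=C(O)COc1cccc(NC(=O)c2ccc(Oc3ccccc3)cc2)c1` — in an assay on isolated protein for agonist activity at Bile acid receptor (Homo sapiens), read by TR-FRET, with a stated time of 3 h, in the absence of a further agent (a lower number here means that less compound is needed, a higher number that more compound is needed for the effect), compound 1 gives only a limit, > 10000 nM.
Compound 2, `CCCOc1cccc(C(=O)Nc2cccc(C(=O)O)c2)c1` — in this assay compound 2 gives 2150 nM.

Among the compounds with values here, compound 2 stands as the only actual number among the two results; the other result, that of compound 1, sits at a limit (the limit of > 10000 nM in this assay, at which 1 of the 2 values shown sits). Compound 3, `O=C(O)c1cccc(NC(=O)c2cccc(OCc3ccccc3)c2)c1`, has not yet been measured in this assay. It differs from compound 2 in one place: phenyl in place of ethyl on a saturated chain carbon bound to an oxygen on an aromatic ring. Within the data shown here, no two measured compounds differ in a single place, so there is no measured step of this kind to lean on, and the expectation rests on compound 2 alone. The expected step in this assay from compound 2 to compound 3 is a 1.5-fold lower number from compound 2 to compound 3 (0.19 log units; within the scatter), a change that may well stay within the usual scatter, leaning toward less compound being needed. Compound 3 is therefore expected to give about 1400 nM in this assay, with a range from 400 nM to 6000 nM.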

Compound 3, half-maximal effective concentration: 1160 nM
Beside the measured number, compound 3's estimate is 1.2-fold (0.08 log units) above it; the range from low to high includes it.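

In this assay, replacing propoxy with benzyloxy gives a 1.9-fold lower number from compound 2 to compound 3 (0.27 log units; within the scatter). Within the data shown here, this is the only measured step at this place, and it shows that a phenyl ring can stand in place of ethyl on this saturated chain carbon without a change that rises above the scatter of repeated measurements, so compound 2 and compound 3 cannot be told apart here. Compound 3 gives a true number, and compound 1 remains the only compound at a limit: the limit of > 10000 nM in this assay, at which 1 of the 3 values shown sits.

The compounds shown leave open whether a longer chain, or an amine at the end of the chain, would move the number beyond that scatter. Compound 1 differs from the other two compounds in more than one place, so its limit cannot be tied to any single change.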